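Phenoxy ring without chlorine: expectation for compound 4

A few compounds are considered here, and "the series" means these few. Any claim that something is new, unique, unknown or untested is made for them only; others in the source may bear on it.

Compound 1 `NC1=NC2(CCOCC2)N(OCCCOc2cccc(Cl)c2)C(N)=N1` gives 520 nM in a functional assay on HL-60 cells (Homo sapiens) for antiproliferative activity, read by MTT assay, with a stated time of 72 h (a lower number here means a stronger inhibitor, a higher number a weaker inhibitor), the lowest of the three numbers shown. Compound 3 `NC1=NC2(CCOCC2)N(OCCCOc2ccccc2Cl)C(N)=N1` gives 660 nM, and the step of a 1.3-fold higher number from compound 1 to compound 3 (0.10 log units; within the scatter) stays within the scatter. Compound 2 `NC1=NC2(CCOCC2)N(OCCCOc2cc(Cl)c(Cl)cc2Cl)C(N)=N1` gives 2360 nM; the step of a 4.5-fold higher number from compound 1 to compound 2 (0.66 log units; beyond the scatter) is the one clear shift in the set. Compound 4 `NC1=NC2(CCOCC2)N(OCCCOc2ccccc2)C(N)=N1` carries hydrogen in place of chloro on an aromatic carbon. For the measured compounds named here, no measured step removes the last chloro to leave a plain phenoxy. The step of a 3.6-fold lower number from compound 2 to compound 3 (0.55 log units; beyond the scatter) ran toward a lower number, and the step from compound 1 to compound 3, 2-chlorophenyl in place of 3-chlorophenyl, changed little. Compound 4 is therefore expected to show a step of a 1.3-fold higher number from compound 1 to compound 4 (0.13 log units; within the scatter) that likely stays within the scatter. The estimate for compound 4 is 700 nM, between 300 nM and 1600 nM.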

Compound 4, half-maximal inhibitory concentration: 2460 nM
The estimate for compound 4 lay 3.5-fold (0.55 log units) below the measured number; the measured number lies above the stated range.
By their numbers in this assay, from the lowest: compounds 1 and 3 (each within the scatter of the next); then compounds 2 and 4 (each within the scatter of the next).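

In this assay the step of a 4.7-fold higher number from compound 1 to compound 4 (0.67 log units; beyond the scatter) and the step of a 3.7-fold higher number from compound 3 to compound 4 (0.57 log units; beyond the scatter) show that a single chloro on the phenoxy ring counts, whichever of the two placements carries it, something the swap between those placements could not show. The step of a 1.0-fold higher number from compound 2 to compound 4 (0.02 log units; within the scatter) sets phenyl level with 2,4,5-trichlorophenyl, so the numbers do not follow chlorine count: compounds 1 and 3 sit lower than both compound 2 and compound 4. Nothing available accounts for this. Open, as far as these compounds go, is whether fluoro or methoxy in place of the chloro would hold the number of compound 1, and whether a longer chain to the phenoxy ring would keep the chloro step.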